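Swapping an aminopyrazine arm for a hydroxyphenyl arm

This account rests on a few compounds, and the source may have more. Where it says the series, first, only, none or still open, it means among the compounds named here.

Three measured compounds share one core and differ only in the aryl group attached at the same aromatic carbon. Compound 1 `Cc1nc2c3ccccc3ccc2c2nc3c(ccc4ccccc43)c(-c3cccc([N+](=O)[O-])c3)c12` gives 117 ug/mL in a functional assay, read by spectrophotometry, with a stated time of 30 min; a lower number here means a stronger inhibitor, a higher number a weaker inhibitor; compound 2 `Cc1nc2c3ccccc3ccc2c2nc3c(ccc4ccccc43)c(-c3nccnc3N)c12` gives 81.7 ug/mL; compound 3 `Cc1nc2c3ccccc3ccc2c2nc3c(ccc4ccccc43)c(-c3cc([N+](=O)[O-])ccc3N)c12` gives 93.1 ug/mL. Compound 2 has the smallest of the three numbers, but the step of a 1.4-fold lower number from compound 1 to compound 2 (0.16 log units; within the scatter) and the step of a 1.1-fold higher number from compound 2 to compound 3 (0.06 log units; within the scatter) are both within the scatter, as is a 1.3-fold lower number from compound 1 to compound 3 (0.10 log units; within the scatter). Compound 4 `Cc1nc2c3ccccc3ccc2c2nc3c(ccc4ccccc43)c(-c3ccc(O)cc3)c12` carries a different arm at that carbon: 4-hydroxyphenyl in place of 3-aminopyrazin-2-yl on an aromatic carbon. Among the compounds with values here, the steps that bear on this change are the two in which the aryl group itself was exchanged at this position, a 1.4-fold lower number from compound 1 to compound 2 (0.16 log units; within the scatter) and a 1.1-fold higher number from compound 2 to compound 3 (0.06 log units; within the scatter), and neither left the scatter. Three rather different aryl groups thus gave close numbers in this assay , and one expects the 4-hydroxyphenyl group to behave alike, so that the expected step of a 1.1-fold higher number from compound 2 to compound 4 (0.04 log units; within the scatter) amounts to nothing beyond the scatter. Compound 4 is therefore estimated at 90 ug/mL, with a range from 40 ug/mL to 200 ug/mL.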

Compound 4, half-maximal inhibitory concentration: 86.4 ug/mL
Compound 4: the middle estimate sits 1.0-fold (0.02 log units) above what was measured; the range from low to high includes it.
By their numbers in this assay, from the lowest: compounds 2, 4, 3 and 1 (each within the scatter of the next).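

In this assay, the 4-hydroxyphenyl arm stays close to all three earlier aryl groups: a 1.1-fold higher number from compound 2 to compound 4 (0.02 log units; within the scatter), a 1.1-fold lower number from compound 3 to compound 4 (0.03 log units; within the scatter) and a 1.4-fold lower number from compound 1 to compound 4 (0.13 log units; within the scatter). Within the data shown here, compound 4 is the first of the series with neither an amino nor a nitro group on the arm, and its exchange with compound 2 replaces a ring with 2 hetero atoms by a ring of carbon only, and 3 hydrogen-bond acceptors by 1, without the step leaving the scatter. Nothing available explains why these arms read alike.

Going by these compounds, it remains open whether a carboxylic acid, a saturated amine such as piperidine or a longer alkyl chain at this carbon would move the number beyond the scatter. On these data alone, whether plain phenyl would read differently from 4-hydroxyphenyl also remains open.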